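This account rests on a few compounds, and the source may have more. Where it says the series, first, only, none or still open, it means among the compounds named here.

Compound 3 `C=CC1=C(C(=O)NCCC)C(c2ccc(OC)cc2)OC1` carries a propyl group on the amide nitrogen of the shared core. In a functional assay on QGY7701 cells (Homo sapiens) for cytotoxicity, read by MTT assay, with a stated time of 24 h (a lower number here means a stronger inhibitor, a higher number a weaker inhibitor), compound 3 gives > 100000 nM, which is a limit of the assay rather than a measured number. Compound 1 `C=CC1=C(C(=O)NCc2ccccc2)C(c2ccc(OC)cc2)OC1` has a benzyl group in that place, and in this assay compound 1 gives > 100000 nM, again a limit. Compound 2 `C=CC1=C(C(=O)NC(C)(C)C)C(c2ccc(OC)cc2)OC1`, with a tert-butyl group there, gives > 100000 nM in this assay, also a limit. All three values therefore sit at the limit of > 100000 nM in this assay, at which 3 of the 3 values shown sit. None of the steps among them can be sized: a step that the two limits leave unreadable from compound 1 to compound 3, a step that the two limits leave unreadable from compound 1 to compound 2 and a step that the two limits leave unreadable from compound 2 to compound 3. Compound 4 `C=CC1=C(C(=O)NCc2ccccc2F)C(c2ccc(OC)cc2)OC1` differs from compound 3 in one place: 2-fluorophenyl in place of ethyl on a saturated chain carbon bound to an amide-type nitrogen. For the measured compounds named here, the step that comes closest to this change is the one from compound 1 to compound 3, where phenyl gave way to ethyl with both ends resting at the limit; the change to compound 4 runs the other way and brings in a fluorine on the ring. With no readable step to build on, no shift beyond the scatter can be foreseen, and the expected step in this assay is a step that the limit leaves unreadable from compound 3 to compound 4. Compound 4 is accordingly estimated at 150000 nM, with a range from 50000 nM to 500000 nM, most likely reported once more as a limit.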

Compound 4, half-maximal inhibitory concentration: > 100000 nM
Compound 4 ended at the assay's limit; the forecaster's own chance of this, stated with the estimate: 85%; the middle value lies beyond the limit too.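

Compound 4 gives > 100000 nM, which is a limit of the assay and not a number. For the compounds shown here, no step from compound 1, compound 2 or compound 3 to compound 4 can be read, because all four compounds rest at the same limit: the limit of > 100000 nM in this assay, at which 4 of the 4 values shown sit. The compounds shown leave open whether any group on the amide nitrogen would give a measurable value in this assay.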